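This account rests on a few compounds, and the source may have more. Where it says the series, first, only, none or still open, it means among the compounds named here.

Measured compounds:
compound 1, `N#Cc1c(F)c(Cl)c2nc(N)nc(N)c2c1F`: 30.8 ug/mL
compound 2, `N#Cc1c(Nc2ccccc2)c(Cl)c2nc(N)nc(N)c2c1F`: > 1000 ug/mL
compound 3, `N#Cc1c(Nc2ccccc2)c(F)c2nc(N)nc(N)c2c1F`: > 1000 ug/mL

In a functional assay on A549 cells (Homo sapiens) for cytotoxicity, read by MTT assay (a lower number here means a stronger inhibitor, a higher number a weaker inhibitor), compound 1 gives 30.8 ug/mL. For compound 2 the reported value is only a limit of the assay, not a number, namely (the limit of > 1000 ug/mL in this assay, at which 2 of the 3 values shown sit). Compound 3 also reaches only that limit. The step of an at least 32-fold higher number from compound 1 to compound 2 (1.51 log units; beyond the scatter) is large, while the step that the two limits leave unreadable from compound 2 to compound 3 cannot be sized. Compound 4, `COc1ccc(Nc2c(C#N)c(F)c3c(N)nc(N)nc3c2Cl)cc1`, differs from compound 2 by methoxy in place of hydrogen on an aromatic carbon. Going by the values given here, no measured step touches this group, and compound 2 itself stands only at a limit, so compound 4 is expected to remain at or near that limit, with a step of a number no higher from compound 2 to compound 4 (the limit leaves the size open) in this assay that is not readable against the scatter. The estimate for compound 4 is 1000 ug/mL, ranging from 300 ug/mL to 3000 ug/mL.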

Compound 4, half-maximal inhibitory concentration: 103 ug/mL
Compound 4: the middle estimate sits 9.7-fold (0.99 log units) above what was measured; measured number outside the range, below it.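

Going from phenyl to 4-methoxyphenyl gives an at least 9.7-fold lower number from compound 2 to compound 4 (0.98 log units; beyond the scatter) in this assay. This shows that a compound carrying the anilino group can come back from the limit, and that a change on this outer ring can be read at all. Compound 2 has only a limit, not a number, so this step has a minimum size but no exact one: the limit of > 1000 ug/mL in this assay, at which 2 of the 4 values shown sit.

From the compounds shown here alone, it remains open whether another group at this place, such as an amine or a longer ethoxy chain, would lower the number as well. Going by these compounds, it is also open whether compound 3, which likewise stands only at a limit, would respond to methoxy in the same way.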